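Ring Nitrogen Entering the Weakest Aryl Amide

The source may hold more compounds than are shown below. What is called first, only, known or untested is meant among the compounds shown, and "the series" means these compounds.

Three amides on one shared core have been measured in a functional assay on HEK293 cells for agonist activity at probable G-protein coupled receptor 27 (Homo sapiens), read by a luciferase reporter and beta-arrestin recruitment, with a stated time of 10 min; on this read-out lower numbers stand for an effect already at smaller amounts and higher numbers for an effect only at larger amounts of compound. Compound 1 `O=C(Nc1ccc(S(=O)(=O)Nc2ccccc2)cc1)c1cc(F)c(Cl)cc1F` gives 141 nM. Compound 2 `Cc1cc(Cl)ccc1C(=O)Nc1ccc(S(=O)(=O)Nc2ccccc2)cc1` gives 912 nM, and compound 3 `O=C(Nc1ccc(S(=O)(=O)Nc2ccccc2)cc1)c1ccc(Cl)cc1F` gives 3980 nM, the highest number of the three. The steps are a 28-fold higher number from compound 1 to compound 3 (1.45 log units; beyond the scatter) and a 4.4-fold higher number from compound 2 to compound 3 (0.64 log units; beyond the scatter), so compound 3 stands apart from both other compounds by more than the scatter, and the step of a 6.5-fold higher number from compound 1 to compound 2 (0.81 log units; beyond the scatter) separates the other two as well.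

Compound 4 `O=C(Nc1ccc(S(=O)(=O)Nc2ccccc2)cc1)c1ccc(Cl)nc1F` differs from compound 3 in one place: 6-chloro-2-fluoropyridin-3-yl in place of 4-chloro-2-fluorophenyl on a carbonyl carbon. Among the measured compounds shown here, none of the measured steps changes a ring atom of that aryl group; the steps that bear on this position alter only the groups carried on its carbons, and those steps ranged from modest to large. For the measured compounds named here, the ring nitrogen of the entering group thus has no measured precedent in this set, and the expected step is one no larger than the scatter, a 1.0-fold higher number from compound 3 to compound 4 (0.00 log units; within the scatter), in either direction. Compound 4 is estimated at 4000 nM, within 1000 nM to 16000 nM.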

Compound 4, half-maximal effective concentration: 2290 nM
The estimate for compound 4 lay 1.7-fold (0.24 log units) above the measured number, within the range that was stated.
By their numbers in this assay, from the lowest: compound 1; then compound 2; then compounds 4 and 3 (each within the scatter of the next).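

In this assay, among the compounds shown here, a ring nitrogen enters the aryl group on the carbonyl carbon for the first time, and the 6-chloro-2-fluoropyridin-3-yl group gives a 1.7-fold lower number from compound 3 to compound 4 (0.24 log units; within the scatter), so this change of a ring atom is not separated from the 4-chloro-2-fluorophenyl group. The entering group still stands apart from the other two aryl groups, with a 2.5-fold higher number from compound 2 to compound 4 (0.40 log units; beyond the scatter) and a 16-fold higher number from compound 1 to compound 4 (1.21 log units; beyond the scatter), so the added ring nitrogen and its hydrogen-bond acceptor do not close either gap. Nothing measured here bears on how the ring nitrogen acts at this position.

The compounds shown leave open whether a ring nitrogen would be tolerated as well within the 4-chloro-2,5-difluorophenyl group of compound 1. They also leave open what an amine or a methoxy group would do in place of the chloro group on the 6-chloro-2-fluoropyridin-3-yl ring of compound 4.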